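Pyridin-2-yl for phenyl on the ring amine nitrogen

This account rests on a few compounds, and the source may have more. Where it says the series, first, only, none or still open, it means among the compounds named here.

Measured in a functional assay on MCF7 cells (Homo sapiens) for antiproliferative activity, read by MTT assay; on this read-out lower numbers stand for stronger inhibition and higher numbers for weaker inhibition:
- compound 1 `c1ccc2c(c1)ccn2-c1nc(N2CCNCC2)nc2ccccc12` gives 14.1 ug/mL
- compound 2 `c1ccc(N2CCN(c3nc(-n4ccc5ccccc54)c4ccccc4n3)CC2)cc1` gives 50 ug/mL
- compound 3 `COc1cc(OC)c(-c2nc(N3CCNCC3)nc3ccccc23)c(OC)c1` gives 50 ug/mL

Compound 2 stands level with compound 3 and shares the highest number of the three, with compound 1 clearly lower. Compound 4 `c1ccc(N2CCN(c3nc(-n4ccc5ccccc54)c4ccccc4n3)CC2)nc1` carries pyridin-2-yl in place of phenyl on an amine nitrogen in a ring and is still to be measured. For the measured compounds named here, the only measured step at this nitrogen is modest, a 3.5-fold higher number from compound 1 to compound 2 (0.55 log units; beyond the scatter) with phenyl replacing hydrogen, and no measured step exchanges one aromatic ring for another. In this assay the expected change is therefore small, a 1.2-fold lower number from compound 2 to compound 4 (0.08 log units; within the scatter) and so no step beyond the scatter. For compound 4 the estimate is 42 ug/mL with an expected range of 20 ug/mL to 80 ug/mL in this read-out.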

Compound 4, half-maximal inhibitory concentration: 50 ug/mL
Estimate against measurement, compound 4: 1.2-fold (0.08 log units) below, and the stated range covers the measured number.
By their numbers in this assay, from the lowest: compound 1; then compounds 2, 3 and 4 (each within the scatter of the next).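

In this assay, exchanging one aromatic ring for another on the amine nitrogen in a ring, with pyridin-2-yl entering for phenyl and one hydrogen-bond acceptor gained, gives no change at the digits printed from compound 2 to compound 4 (within the scatter) and so leaves the read-out unmoved. Measured against hydrogen at this nitrogen, pyridin-2-yl gives a 3.5-fold higher number from compound 1 to compound 4 (0.55 log units; beyond the scatter) in the same direction as phenyl, so both aromatic rings now separate from compound 1. No measured evidence bears on this result.

From the compounds shown here alone, whether a small alkyl group such as methyl on this nitrogen also separates from compound 1 remains open. So does the effect of an amine or a carboxylic acid on the pyridin-2-yl ring.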